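A few compounds are considered here, and "the series" means these few. Any claim that something is new, unique, unknown or untested is made for them only; others in the source may bear on it.

In a functional assay on CHO-K1 cells for agonist activity at Glucose-dependent insulinotropic receptor (Mus musculus), read by HTRF and cAMP accumulation, with a stated time of 30 min (a higher number here means that more compound is needed for the effect, a lower number that less compound is needed), three compounds have been measured so far. Compound 3, `CC(C)(C)OC(=O)N1CCC(CCCNc2ccc3c(c2)C(=O)CC3)CC1`, gives 123 nM. Compound 1, `CCc1cnc(N2CCC(CCCNc3ccc4c(c3)C(=O)CC4)CC2)nc1`, gives 167 nM. These two differ in a single place: 5-ethylpyrimidin-2-yl in place of tert-butoxycarbonyl on an amine nitrogen in a ring That swap made a 1.4-fold higher number from compound 3 to compound 1 (0.13 log units; within the scatter). Compound 2, `CC(C)(C)OC(=O)N1CCC(CCCNc2ccc3c(c2)OCC3=O)CC1`, gives 66 nM. Its core is not the same as that of compound 3, but the difference between the two cores is not broken down here.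

Compound 4, `CCc1cnc(N2CCC(CCCNc3ccc4c(c3)OCC4=O)CC2)nc1`, has not yet been measured. It carries the core of compound 2 and differs from compound 2 by the same change seen between compound 3 and compound 1: 5-ethylpyrimidin-2-yl in place of tert-butoxycarbonyl on an amine nitrogen in a ring Because this change made a 1.4-fold higher number from compound 3 to compound 1 (0.13 log units; within the scatter), a step of similar size is expected from compound 2 to compound 4, namely a 1.4-fold higher number from compound 2 to compound 4 (0.14 log units; within the scatter). This expectation rests on one measured pair only, so it is a rough guide rather than a firm rule. Compound 4 is therefore estimated at 92 nM, most likely falling between 45 nM and 190 nM.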

Compound 4, half-maximal effective concentration: 159 nM
Estimate against measurement, compound 4: 1.7-fold (0.24 log units) below; the measured number falls inside the stated range.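

In this assay, putting 5-ethylpyrimidin-2-yl in place of tert-butoxycarbonyl on the core of compound 2 gives a 2.4-fold higher number from compound 2 to compound 4 (0.38 log units; beyond the scatter), and this step can be set beside the same change on the other core: the same change on two cores in this assay, a 1.4-fold higher number (0.13 log units; within the scatter) from compound 3 to compound 1 and a 2.4-fold higher number (0.38 log units; beyond the scatter) from compound 2 to compound 4, 1.8-fold (0.25 log units) apart, within the scatter of two such steps. The two steps cannot be told apart, which means that in this small set the change behaves alike on both cores, and a step measured on one core served as a usable rough guide for the other. For the compounds shown here, this does not show a general rule or that the two steps are truly equal, since it rests on just two pairs of compounds and only the step on the core of compound 2 lies beyond the scatter on its own.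

The compounds shown leave open how other groups on the ring nitrogen would fit this picture, such as a pyrimidin-2-yl without the ethyl group or a simple acetyl amide. They also leave open whether the change would carry over as well with a longer chain linking the two ends of the molecule, or on a third core.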